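The compounds below may be only part of what the source reports. "The series", "measured", "known", "first", "only" and "open" are said of these compounds alone.

Measured so far:
- compound 1, `O=C(CSc1nc(Nc2ccccc2)c2ccccc2n1)Nc1ccc(Cl)cc1`: 12900 nM
- compound 2, `O=C(CSc1nc(Nc2ccccc2)c2ccccc2n1)Nc1ccc([N+](=O)[O-])cc1`: 25000 nM
- compound 3, `C=CC(=O)Nc1cccc(NC(=O)CSc2nc(Nc3ccccc3F)c3ccccc3n2)c1`: 9340 nM

In a functional assay on PC-3 cells (Homo sapiens) for inhibition, read by MTT assay, with a stated time of 72 h (a lower number here means a stronger inhibitor, a higher number a weaker inhibitor), compound 3 shows the lowest of the three numbers. Its gap to compound 1 lies within the scatter, so the two cannot be told apart; only its gap to compound 2 lies beyond it.

Compound 4, `C=CC(=O)Nc1cccc(NC(=O)CSc2nc(Nc3ccc(F)cc3)c3ccccc3n2)c1`, has not yet been measured. It differs from compound 3 in one place: 4-fluorophenyl in place of 2-fluorophenyl on a nitrogen on an aromatic ring. Among the compounds with values here, the only measured step, a 1.9-fold higher number from compound 1 to compound 2 (0.29 log units; within the scatter), exchanges one group on the amide side of the shared core and so does not touch the part that changes here. Within the data shown here, nothing measured bears directly on moving the fluorine from 2-fluorophenyl to 4-fluorophenyl, and the one step that is known stayed within the scatter. The expectation for compound 4 in this assay is therefore a step of a 1.0-fold higher number from compound 3 to compound 4 (0.01 log units; within the scatter), that is, nothing beyond the scatter. Compound 4 is estimated at 9500 nM, with a range from 4000 nM to 22000 nM.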

Compound 4, half-maximal inhibitory concentration: 8240 nM
Estimate against measurement, compound 4: 1.2-fold (0.06 log units) above; low and high end bracket the measured number.
By their numbers in this assay, from the lowest: compounds 4, 3, 1 and 2 (each within the scatter of the next, the first and the last beyond it).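

Within the data shown here, the new pair gives the first direct look at the aromatic group on this nitrogen, which the earlier step between compound 1 and compound 2 left untouched. In this assay, 4-fluorophenyl in place of 2-fluorophenyl gives a 1.1-fold lower number from compound 3 to compound 4 (0.05 log units; within the scatter), so for this pair the place of the fluorine on the phenyl ring makes no difference that can be told from the scatter. No measurement at hand accounts for this result.

Still open, from the compounds shown here alone, is whether a different group on this ring, such as an amine or a carboxylic acid, would shift the number beyond the scatter. Also open, going by these compounds, is what the fluorine itself adds: compound 1 and compound 2 carry a plain phenyl there, but they differ from compound 4 in a second place as well.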